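Returning to an alkyl group on the amide nitrogen

A few compounds are considered here, and "the series" means these few. Any claim that something is new, unique, unknown or untested is made for them only; others in the source may bear on it.

Compound 1, `Cc1ccc(OCC(=O)N(Cc2cccs2)CC(C)C)cc1`, in an assay on HEK293 cells for agonist activity at transient receptor potential cation channel subfamily M member 8 (Homo sapiens), read by fluorescence and calcium flux, with a stated time of 15 min (on this read-out lower numbers stand for an effect already at smaller amounts and higher numbers for an effect only at larger amounts of compound), gives 900 nM.
Compound 2, `Cc1ccc(OCC(=O)N(CCO)Cc2cccs2)cc1`, gives 900 nM.
Compound 3, `Cc1ccc(OCC(=O)N(Cc2cccs2)c2ccncc2)cc1`, gives 52 nM.

Compound 3 has the lowest number of the three. Compound 4, `Cc1ccc(OCC(=O)N(Cc2cccs2)C(C)C)cc1`, differs from it by isopropyl in place of pyridin-4-yl on an amide-type nitrogen. Among the measured compounds shown here, the steps that bear on this are a 17-fold lower number from compound 1 to compound 3 (1.24 log units; beyond the scatter) and a 17-fold lower number from compound 2 to compound 3 (1.24 log units; beyond the scatter), both large and both beyond the scatter, and both came from putting pyridin-4-yl onto the amide-type nitrogen in place of a saturated group. Compound 4 undoes that kind of change, so a large step to a higher number is expected, about a 15-fold higher number from compound 3 to compound 4 (1.19 log units; beyond the scatter). Compound 4 is therefore estimated at 800 nM, with a range from 300 nM to 2500 nM, close to where compound 1 and compound 2 stand.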

Compound 4, half-maximal effective concentration: 70 nM
The estimate for compound 4 lay 11-fold (1.06 log units) above the measured number; measured number below the stated range.
By their numbers in this assay, from the lowest: compounds 3 and 4 (each within the scatter of the next); then compounds 1 and 2 (each within the scatter of the next).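

A pyridin-4-yl ring on the amide-type nitrogen turns out not to be required for a low number, since the step of a 1.3-fold higher number from compound 3 to compound 4 (0.13 log units; within the scatter) shows isopropyl serving equally well. Saturated groups at this place also differ sharply among themselves, with a 13-fold lower number from compound 1 to compound 4 (1.11 log units; beyond the scatter) and a 13-fold lower number from compound 2 to compound 4 (1.11 log units; beyond the scatter) as isopropyl replaces isobutyl or 2-hydroxyethyl. No supporting measurement explains these steps.

Still open, as far as these compounds go, is where a cyclopropyl or tert-butyl group on this nitrogen would fall. A phenyl ring there, without the ring nitrogen of pyridin-4-yl, is equally unresolved.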